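The compounds below may be only part of what the source reports. "The series", "measured", "known", "first", "only" and "open" are said of these compounds alone.

Compound 1 `Cc1oc2c([C@H]3CCN(C)C[C@H]3O)c(O)cc(O)c2c(=O)c1C(O)c1cccc(Cl)c1` and compound 2 `Cc1oc2c([C@H]3CCN(C)C[C@H]3O)c(O)cc(O)c2c(=O)c1C(O)c1cccc(Cl)c1Cl` share a core and differ in one group, their difference being (chloro in place of hydrogen on an aromatic carbon). In a functional assay on MIA PaCa-2 cells (Homo sapiens) for inhibition, read by MTT assay, with a stated time of 48 h, tested at 10 uM (a higher number here means more inhibition of growth at the concentration tested, a lower number less inhibition of growth), compound 1 gives 2%, and compound 2 gives 2%; the step of no change at the digits printed from compound 1 to compound 2 (within the scatter). Compound 3 `CN1CC[C@H](c2c(O)cc(O)c3c(=O)cc(/C=C/c4ccccc4)oc23)[C@H](O)C1` carries a different core; how it differs from compound 1 is not broken down here. In this assay compound 3 gives 87%, the highest of the three numbers, with both compound 1 and compound 2 standing far lower, beyond the scatter.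

Compound 4 `CN1CC[C@H](c2c(O)cc(O)c3c(=O)cc(/C=C/c4ccc(Cl)cc4)oc23)[C@H](O)C1` has not yet been measured. Among the compounds with values here, it differs from compound 3 by chloro in place of hydrogen on an aromatic carbon, which is the same kind of change as the one from compound 1 to compound 2, though not the same: in compound 2 the chloro sits ortho to a chloro group and ortho to a large group, whereas in compound 4 it sits para to a large group, on a ring of carbon only. The earlier step, measured from compound 1 to compound 2, made no difference within the scatter, though both numbers there lie near the bottom of the scale, so it says little about what this change does to a compound that already inhibits strongly. Resting on that single precedent and on the high number of compound 3, the expected step is a number 3 percentage points lower from compound 3 to compound 4 (within the scatter), which is to say little change. Compound 4 is therefore estimated at 84% in this assay, within a range from 65% to 95%.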

Compound 4, percent growth inhibition at one concentration: 88%
The estimate for compound 4 lay 4 percentage points below the measured number; the range from low to high includes it.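

On the core of compound 3, chloro in place of hydrogen on an aromatic carbon, here para to a large group, gives a number 1 percentage points higher from compound 3 to compound 4 (within the scatter). In this assay, this step and the earlier one agree, so the change carries over from one core to the other in the sense that neither step moves the number beyond the scatter and the two steps do not differ from each other: the same change on two cores in this assay, no change at the digits printed (within the scatter) from compound 1 to compound 2 and a number 1 percentage points higher (within the scatter) from compound 3 to compound 4, 1 percentage points apart, within the scatter of two such steps

Within the data shown here, this does not show that the change is without effect in general, as there is only one pair on each core, the chloro sits at a different place in each pair, and the two pairs lie at opposite ends of the scale, with compound 1 at 2% and compound 3 at 87%, so a single tested concentration could hide differences in either pair.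

The compounds shown leave open what a group other than chloro, such as methoxy, an amine or a carboxylic acid, would do on the phenyl of the 2-phenylethenyl group. They also leave open how compound 3 and compound 4 would compare at lower concentrations, where numbers at this level might separate.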